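A few compounds are considered here, and "the series" means these few. Any claim that something is new, unique, unknown or untested is made for them only; others in the source may bear on it.

Measured so far in a functional assay on MCF7 cells (Homo sapiens) for cytotoxicity, read by MTT assay, with a stated time of 24 h; on this read-out higher numbers stand for weaker inhibition and lower numbers for stronger inhibition:

- compound 1 `O=C1/C(=C/c2ccccc2F)CN(Cc2cn(Cc3ccccc3F)nn2)C/C1=C\c1ccccc1F`: 6000 nM
- compound 2 `O=C1/C(=C/c2ccccc2F)CN(C(=S)SCc2cn(Cc3ccccc3F)nn2)C/C1=C\c1ccccc1F`: 51600 nM

Of these two compounds, compound 1 has the lower number at 6000 nM, while compound 2 gives 51600 nM. The gap between them lies beyond the usual scatter of repeated measurements, so compound 1 is the stronger inhibitor of the pair in this assay.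

The next compound to be tested is compound 3 `O=C1/C(=C/c2ccccc2F)CN(Cc2cn(Cc3ccccc3Cl)nn2)C/C1=C\c1ccccc1F`. It differs from compound 1 in a single place, where a 2-fluorobenzyl becomes a 2-chlorobenzyl: chloro in place of fluoro on an aromatic carbon. The rest of the structure stays the same.

Within the data shown here, no measured pair here shows what this swap does, so the only anchor is compound 1 at 6000 nM. With so small a change, no step beyond the scatter is expected in this assay, though the uncertainty is wide in either direction. The estimated step is a 1.1-fold higher number from compound 1 to compound 3 (0.03 log units; within the scatter). For compound 3 the expected value is 6500 nM, with an estimated range from 2500 nM to 17000 nM.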

Compound 3, half-maximal inhibitory concentration: 10000 nM
For compound 3 the middle estimate is 1.5-fold (0.19 log units) below the measured one; low and high end bracket the measured number.
By their numbers in this assay, from the lowest: compounds 1 and 3 (each within the scatter of the next); then compound 2.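

In this assay, replacing the 2-fluorobenzyl with a 2-chlorobenzyl gives a 1.7-fold higher number from compound 1 to compound 3 (0.22 log units; within the scatter), so at this place, on an aromatic carbon of a six-membered aromatic ring of carbon only and ortho to a large group, the two halogens cannot be told apart. Among these compounds, this is the first pair that tests this position, and it shows that the change of one halogen for another, with no hydrogen-bond donors or acceptors and no net charge entering or leaving, does not shift the read-out beyond the normal noise of the measurement. Nothing measured here gives a reason for this result, and a small step like this one needs no special explanation.

This single swap cannot show whether the position is insensitive to substitution in general, so a plain hydrogen, a bromo, a methyl, a methoxy, a trifluoromethyl or an amine at this place could still give a clearly different number. From the compounds shown here alone, it also remains open whether the 2-fluorophenyl groups on the shared core respond to the same swap in the same way.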